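The compounds below may be only part of what the source reports. "The series", "measured", "known", "first", "only" and "open" are said of these compounds alone.

Working notes on the series. The shared core of compound 1 `CS(=O)(=O)Nc1ccc2[nH]c(Cc3ccc(Oc4ccccc4)cc3)nc2c1` carries a methylsulfonyl-amino group; in an assay on membranes from brain for binding affinity to Adrenergic receptor alpha-1 (Rattus norvegicus) (on this read-out lower numbers stand for stronger inhibition and higher numbers for weaker inhibition), compound 1 gives 4000 nM. Compound 2 `CCCS(=O)(=O)Nc1ccc2[nH]c(Cc3ccc(Oc4ccccc4)cc3)nc2c1` extends the chain on the sulfonyl side, and in this assay compound 2 gives 4800 nM. The only measured step, a 1.2-fold higher number from compound 1 to compound 2 (0.08 log units; within the scatter), lies within the scatter, so compound 2 stands together with compound 1 on the numbers shown and nothing separates the two.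

The next compound, compound 3 `CN(c1ccc2[nH]c(Cc3ccc(Oc4ccccc4)cc3)nc2c1)S(C)(=O)=O`, differs from compound 2 by methyl(methylsulfonyl)amino in place of (propylsulfonyl)amino on an aromatic carbon. This change has two parts: the chain on the sulfonyl sulfur goes back to a single carbon, and the hydrogen-bond donor on the nitrogen is replaced by a methyl. Within the data shown here, the first part is covered by the step from compound 1 to compound 2, which was within the scatter; no measured step bears on the second part, so the data give no guide to it. The expectation for this assay is therefore a step of about a 1.3-fold higher number from compound 2 to compound 3 (0.10 log units; within the scatter), within the scatter. Compound 3 is estimated at 6000 nM, with a range from 2000 nM to 20000 nM.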

Compound 3, half-maximal inhibitory concentration: 2000 nM
Compound 3: the middle estimate sits 3.0-fold (0.48 log units) above what was measured, within the range that was stated.
By their numbers in this assay, from the lowest: compounds 3, 1 and 2 (each within the scatter of the next, the first and the last beyond it).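

In this assay, among these compounds, the change to methyl(methylsulfonyl)amino on this aromatic carbon gives a 2.4-fold lower number from compound 2 to compound 3 (0.38 log units; beyond the scatter) and is the first step to lie beyond the scatter, although it is modest, so the numbers at this position are no longer all together. Methyl in place of hydrogen on the sulfonamide nitrogen, read alone, gives a 2.0-fold lower number from compound 1 to compound 3 (0.30 log units; within the scatter) and lies within the scatter, so compound 3 stands together with compound 1, and the step beyond the scatter belongs only to the combined change in the sulfonyl chain and on the nitrogen. No measurement on hand accounts for this step.

On these data alone, it remains open whether a propyl chain on the sulfonyl sulfur, combined with the methyl on the sulfonamide nitrogen, would stand with compound 3 or apart from it, which would help separate the two parts of the combined change. Also open, as far as these compounds go, is how a larger group on that nitrogen, such as ethyl or benzyl, or an amide or a carboxylic acid on the same aromatic carbon, would read in this assay on this core.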